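The source may hold more compounds than are shown below. What is called first, only, known or untested is meant among the compounds shown, and "the series" means these compounds.

Measured so far:
compound 1 `COc1cc(-c2nnc(SCc3ccc(Cl)cc3)o2)ccc1O`: 11100 nM
compound 2 `COc1cc(-c2nnc(SCc3ccc(F)cc3)o2)ccc1O`: 8190 nM

Among the measured compounds shown here, in a functional assay on cells (T-cell, Mus musculus, strain BALB/c) for inhibition, read by MTT assay, with stated times of 24 h and 72 h (on this read-out higher numbers stand for weaker inhibition and lower numbers for stronger inhibition), compound 2 stands at the lowest of the two numbers, with compound 1 as its only neighbour; the single measured step, a 1.4-fold lower number from compound 1 to compound 2 (0.13 log units; within the scatter), stays within the scatter, so the two compounds cannot be placed in any order of strength.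

Compound 3 `COc1cc(-c2nnc(SCc3ccccc3C)o2)ccc1O` differs from compound 2 in one place: 2-methylphenyl in place of 4-fluorophenyl on a saturated chain carbon bound to a sulfur. For the measured compounds named here, the one measured step exchanges a halogen on the same aromatic ring and produced no change beyond the scatter; it does not, however, test a methyl group, so it bears on the new change only loosely. On that slender basis the expected step from compound 2 to compound 3 in this assay is a 1.0-fold higher number from compound 2 to compound 3 (0.02 log units; within the scatter), that is, nothing beyond the scatter. The estimate for compound 3 is therefore 8500 nM, with a range from 3000 nM to 25000 nM.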

Compound 3, half-maximal inhibitory concentration: 8420 nM
Beside the measured number, compound 3's estimate is 1.0-fold (0.00 log units) above it, and the stated range covers the measured number.
By their numbers in this assay, from the lowest: compounds 2, 3 and 1 (each within the scatter of the next).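

The change of aryl group at this position goes beyond a swap of one halogen for another: in this assay, the 2-methylphenyl group gives a 1.0-fold higher number from compound 2 to compound 3 (0.01 log units; within the scatter) and a 1.3-fold lower number from compound 1 to compound 3 (0.12 log units; within the scatter). Neither step leaves the scatter, so a methyl group on the ring, carrying no halogen, is tolerated on a saturated chain carbon bound to a sulfur as well as either halogen-bearing ring, and compounds 1, 2 and 3 still cannot be placed in any order of strength. Nothing available offers an explanation for this lack of separation.

From the compounds shown here alone, all three aryl groups are hydrocarbon or halogen-bearing rings, so it remains open whether an amine or a carboxylic acid on the ring would shift the number beyond the scatter. Going by these compounds, whether a longer chain at this position would do so also remains open.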